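The compounds below may be only part of what the source reports. "The series", "measured", "known", "first", "only" and "open" are said of these compounds alone.

The series shares the core of compound 1, `CCCn1c(=O)[nH]c2nc(-c3ccc(S(=O)(=O)N4CCN(c5ccc(Br)cc5)CC4)cc3)[nH]c2c1=O`. In an assay on CHO cells for displacement of a labelled ligand from adenosine receptor A1 (Homo sapiens), read by scintillation counting, with a stated time of 90 min, in the presence of a further agent that is not named here (a higher number here means a weaker inhibitor, a lower number a stronger inhibitor), compound 1 gives only a limit, > 1000 nM, which is the limit of the assay rather than a measured number (the limit of > 1000 nM in this assay, at which 1 of the 3 values shown sits); compound 1 therefore stands at the weak end of the values seen so far. Compound 2, `CCCn1c(=O)[nH]c2nc(-c3ccc(S(=O)(=O)N4CCN(c5ccccc5)CC4)cc3)[nH]c2c1=O`, gives 364 nM in this assay. Compound 3, `CCCn1c(=O)[nH]c2nc(-c3ccc(S(=O)(=O)N4CCN(Cc5ccc(Br)c(F)c5)CC4)cc3)[nH]c2c1=O`, gives 326 nM in this assay. Both an at least 2.7-fold lower number from compound 1 to compound 2 (0.43 log units; beyond the scatter) and an at least 3.0-fold lower number from compound 1 to compound 3 (0.48 log units; beyond the scatter) move away from compound 1, whereas a 1.1-fold lower number from compound 2 to compound 3 (0.05 log units; within the scatter) shows no difference between compound 2 and compound 3.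

Compound 4, `CCCn1c(=O)[nH]c2nc(-c3ccc(S(=O)(=O)N4CCN(c5ccccc5F)CC4)cc3)[nH]c2c1=O`, differs from compound 1 by 2-fluorophenyl in place of 4-bromophenyl on an amine nitrogen in a ring. The measured step that bears on this is an at least 2.7-fold lower number from compound 1 to compound 2 (0.43 log units; beyond the scatter), where hydrogen in place of bromo on an aromatic carbon gave an at least modest fall. Compound 4 likewise lacks the bromo, but brings in a 2-fluorophenyl for which no comparison exists. A fall of about the size seen from compound 1 to compound 2 is expected in this assay. Compound 4 is estimated at 400 nM, with a range from 150 nM to 1500 nM, the expected step being an at least 2.5-fold lower number from compound 1 to compound 4 (0.39 log units; beyond the scatter).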

Compound 4, inhibition constant: > 1000 nM
Compound 4: no number, only a limit; the forecaster's own chance of this, stated with the estimate: 20%; middle value at least 2.5-fold (0.39 log units) away from the limit.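

In this assay compound 4 gives > 1000 nM, a limit and not a number: the limit of > 1000 nM in this assay, at which 2 of the 4 values shown sit.

Fluoro in place of hydrogen on an aromatic carbon is enough to give an at least 2.7-fold higher number from compound 2 to compound 4 (0.43 log units; beyond the scatter), so removing the bromo of compound 1 does not by itself yield a measurable value; the substituent on the phenyl matters even when it is only a 2-fluoro. The change to 2-fluorophenyl from 4-bromo-3-fluorobenzyl gives an at least 3.0-fold higher number from compound 3 to compound 4 (0.48 log units; beyond the scatter), and compound 3 goes against any reading that halogen on the aromatic ring always ends at the limit.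

The step between compound 1 and compound 4 cannot be read, as both are limits. Still open, on these data alone, is whether a methoxy or an amine on the phenyl, or an unsubstituted benzyl, would give a number rather than a limit.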